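The compounds below may be only part of what the source reports. "The series", "measured", "known", "first", "only" and "open" are said of these compounds alone.

Measured in a functional assay on the whole organism with Mus musculus as the target, in the writhing test; on this read-out higher numbers stand for an effect only at larger amounts of compound and lower numbers for an effect already at smaller amounts:
- compound 1 `[O-][S+](CCC(F)(F)C(F)(F)F)c1nc(-c2ccccc2)c(-c2ccccc2)[nH]1`: > 130 mg/kg (a limit)
- compound 2 `O=S(=O)(CCC(F)(F)F)c1nc(-c2ccccc2)c(-c2ccccc2)[nH]1`: > 135 mg/kg (a limit)

Compound 2 has no number on this read-out: its > 135 mg/kg is a limit of this assay. Compound 1 likewise gives only a limit, > 130 mg/kg. For the measured compounds named here, no measured step is available, so the series offers no size of step to go by.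

Compound 3 `O=S(=O)(CCC(F)(F)C(F)(F)F)c1nc(-c2ccccc2)c(-c2ccccc2)[nH]1` differs from compound 2 as follows: trifluoromethyl in place of fluoro on a saturated chain carbon bound to two fluorine atoms and a saturated chain carbon. Trifluoromethyl takes the place of fluoro on a saturated chain carbon bound to two fluorine atoms and a saturated chain carbon, turning 3,3,3-trifluoropropyl into 3,3,4,4,4-pentafluorobutyl. No change beyond the usual scatter is expected in this assay, and a further limit is the likeliest report. This expectation rests on compound 2, whose > 135 mg/kg is a limit. The estimated step is a step that the limit leaves unreadable from compound 2 to compound 3. For compound 3 the estimate is 140 mg/kg, with an expected range of 70 mg/kg to 280 mg/kg.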

Compound 3, dose for half-maximal effect: > 130 mg/kg
Compound 3: no number, only a limit; the forecaster's own chance of this, stated with the estimate: 75%; the middle value is on the limit's open side.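

In this assay compound 3 gives > 130 mg/kg, a limit. For the compounds shown here, compound 2 also stands only as a limit, and no step from compound 2 to compound 3 can be read. The compounds shown leave open whether trifluoromethyl in place of fluoro at this place changes the dose needed in this assay.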